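Shortening the oxetane link on the ring nitrogen

The compounds below may be only part of what the source reports. "The series", "measured", "known", "first", "only" and "open" are said of these compounds alone.

Numbers so far in an assay on isolated protein for inhibition of retinal dehydrogenase 2 (Homo sapiens); on this read-out lower numbers stand for stronger inhibition and higher numbers for weaker inhibition:
compound 1 `Cn1ncc2c(=O)n(-c3ccccc3)c(COc3cccc(F)c3)nc21`: 1770 nM
compound 2 `Cn1ncc2c(=O)n(-c3ccccc3)c(SC(C)(C)c3ccccc3)nc21`: 2200 nM
compound 3 `CC(Sc1nc2nn(CC3COC3)cc2c(=O)n1-c1ccccc1)c1ccccc1`: 80 nM

Compound 3 stands lowest of the three numbers; compound 1 sits above it by a gap beyond the scatter, and compound 2 sits further above still. Compound 4 `CC(Sc1nc2nn(C3COC3)cc2c(=O)n1-c1ccccc1)c1ccccc1` has not been measured. It differs from compound 3 in one place: oxetan-3-yl in place of (oxetan-3-yl)methyl on an aromatic nitrogen. For the measured compounds named here, no step between measured compounds covers this change, so the expectation rests on compound 3 alone. Because compound 3 gives 80 nM in this assay and the change is small, a shift of modest size or none beyond the scatter is expected; the expected step from compound 3 to compound 4 is a 1.5-fold higher number from compound 3 to compound 4 (0.18 log units; within the scatter). Compound 4 is estimated at 120 nM, within 40 nM to 400 nM.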

Compound 4, half-maximal inhibitory concentration: 65 nM
Compound 4: the middle estimate sits 1.8-fold (0.27 log units) above what was measured, and the stated range covers the measured number.
By their numbers in this assay, from the lowest: compounds 4 and 3 (each within the scatter of the next); then compounds 1 and 2 (each within the scatter of the next).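

For the compounds shown here, this pair gives the first single-place reading at this position. In this assay, oxetan-3-yl in place of (oxetan-3-yl)methyl on the aromatic nitrogen gives a 1.2-fold lower number from compound 3 to compound 4 (0.09 log units; within the scatter), so the length of this link does not separate the two compounds. No data available here explain this result.

Both compounds carry the four-membered ring with its oxygen, leaving open whether that ring matters at this nitrogen. Also open, on these data alone, is how an amine, a carboxylic acid or a longer chain would read there.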